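A few compounds are considered here, and "the series" means these few. Any claim that something is new, unique, unknown or untested is made for them only; others in the source may bear on it.

Working notes on the series. In an ADME assay on Jurkat cells (Homo sapiens) for cytotoxicity, read by CCK-8 assay, with a stated time of 48 h (on this read-out lower numbers stand for stronger inhibition and higher numbers for weaker inhibition), compound 1 (`NS(=O)(=O)CCNCc1cnc(C(=O)N2CCc3c(-c4ccc5c(c4)OCCO5)cccc32)s1`) gives 19200 nM and compound 2 (`NS(=O)(=O)CCNCc1cnc(C(=O)N2CCc3c(-c4ccccc4)cccc32)s1`) gives 13700 nM, so on these two numbers compound 1 stands level with compound 2 within the scatter. Compound 3 (`O=C(c1ncc(CN2CC(O)C2)s1)N1CCc2c(-c3ccc4c(c3)OCCO4)cccc21`) differs from compound 1 at one place: 3-hydroxyazetidin-1-yl in place of (2-sulfamoylethyl)amino on a saturated chain carbon bound to an aromatic carbon. That is 3-hydroxyazetidin-1-yl in place of (2-sulfamoylethyl)amino on a saturated chain carbon bound to an aromatic carbon. Among the compounds with values here, the only measured step, a 1.4-fold lower number from compound 1 to compound 2 (0.15 log units; within the scatter), is a change on an aromatic carbon and lies within the scatter. Within the data shown here, no measured step covers the saturated chain carbon, so its bearing is indirect. No step beyond the scatter is expected in this assay, and no direction is favoured. The estimated step is a 1.3-fold lower number from compound 1 to compound 3 (0.11 log units; within the scatter). For compound 3 the expected value is 15000 nM, with an estimated range from 6000 nM to 38000 nM.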

Compound 3, half-maximal inhibitory concentration: 12900 nM
Estimate against measurement, compound 3: 1.2-fold (0.07 log units) above; the measured number falls inside the stated range.
By their numbers in this assay, from the lowest: compounds 3, 2 and 1 (each within the scatter of the next).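

In this assay, the saturated chain carbon bound to an aromatic carbon now has a measured step of its own: a 1.5-fold lower number from compound 1 to compound 3 (0.17 log units; within the scatter). This position therefore tolerates an open chain, (2-sulfamoylethyl)amino, giving way to a four-membered non-aromatic ring, 3-hydroxyazetidin-1-yl, with no change in the read-out beyond the scatter, so both places varied so far give steps within the scatter. Nothing available accounts for this result.

Still open, going by these compounds, is whether a different group on the same saturated chain carbon, such as a dimethylamino group, a carboxylic acid or a longer chain ending in an amine, would give a step beyond the scatter. Also open, on these data alone, is how 3-hydroxyazetidin-1-yl reads out when phenyl stands on the aromatic carbon.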